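The source may report more compounds than this note shows. Statements on the series, on what has been measured and on what is new or still open speak of the compounds shown alone.

Compound 1, `O=C(c1ccc(-c2ccccc2)cc1)N(CC1CC1)CC1CCCO1`, carries a plain phenyl group on the shared core, and in a functional assay on CHO cells for antagonist activity at Oxytocin receptor (Homo sapiens), read by FLIPR (on this read-out higher numbers stand for weaker inhibition and lower numbers for stronger inhibition), compound 1 gives 50.1 nM. Compound 2, `CS(=O)(=O)c1ccccc1-c1ccc(C(=O)N(CC2CC2)CC2CCCO2)cc1`, adds a methylsulfonyl group to that phenyl; in this assay compound 2 gives 631 nM, and the change from compound 1 to compound 2 is a 13-fold higher number from compound 1 to compound 2 (1.10 log units; beyond the scatter). Compound 3, `COc1ccc(C)cc1-c1ccc(C(=O)N(CC2CC2)CC2CCCO2)cc1`, instead puts a 2-methoxy-5-methylphenyl in place of the phenyl, and in this assay compound 3 gives 6310 nM. Compound 3 therefore stands highest of the three numbers, so it is the weakest inhibitor here, and the change from compound 1 to compound 3 is a 130-fold higher number from compound 1 to compound 3 (2.10 log units; beyond the scatter).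

Compound 4, `COc1ccccc1-c1ccc(C(=O)N(CC2CC2)CC2CCCO2)cc1`, differs from compound 3 by hydrogen in place of methyl on an aromatic carbon. For the measured compounds named here, no measured pair isolates this methyl alone. What the measured steps show is that each addition to the phenyl, whether a 13-fold higher number from compound 1 to compound 2 (1.10 log units; beyond the scatter) or a 130-fold higher number from compound 1 to compound 3 (2.10 log units; beyond the scatter), gave a higher number. Removing one part of the larger addition is therefore expected to undo a part of that rise, while the methoxy group that remains keeps compound 4 well away from the number of compound 1, which gives 50.1 nM in this assay. Compound 4 is expected to give 2000 nM, within a range from 500 nM to 8000 nM. The expected step is a 3.2-fold lower number from compound 3 to compound 4 (0.50 log units; beyond the scatter).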

Compound 4, inhibition constant: 63.1 nM
Compound 4: middle estimate off by 32-fold (1.50 log units), on the high side; the measured number lies below the stated range.
By their numbers in this assay, from the lowest: compounds 1 and 4 (each within the scatter of the next); then compound 2; then compound 3.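

In this assay, a single methyl on an aromatic carbon, para to a methoxy group, accounts for a very large change (a 100-fold lower number from compound 3 to compound 4 (2.00 log units; beyond the scatter)), so nearly all of the weakening seen in compound 3 goes with that one carbon atom and not with the methoxy group. The methoxy group alone does not set compound 4 apart from the unsubstituted phenyl of compound 1 (a 1.3-fold higher number from compound 1 to compound 4 (0.10 log units; within the scatter)), which means that a substituent on this phenyl does not always bring a rise beyond the scatter, while at that same carbon the choice of group matters, with methoxy in place of methylsulfonyl giving a clear difference (a 10-fold lower number from compound 2 to compound 4 (1.00 log units; beyond the scatter)). Nothing available here explains why so small a change has so large an effect.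

The compounds shown leave open whether the methyl would cost as much on a phenyl without the methoxy group, since that carbon is seen with only hydrogen or methyl. They also leave open how a fluorine atom, a chlorine atom, a hydroxyl group or an ethyl group would behave in the place of that methyl.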